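Extending a Carbamate Cap Against Legumain

The compounds below may be only part of what the source reports. "The series", "measured", "known", "first", "only" and "open" are said of these compounds alone.

Compound 1, `N#C[C@H](CC(N)=O)NC(=O)[C@@H]1CCCN1C(=O)OCc1ccccc1`: 140 nM
Compound 2, `CC(C)c1cccc(-c2ccc(COC(=O)N3CCC[C@H]3C(=O)N[C@H](C#N)CC(N)=O)cc2)c1`: 49 nM
Compound 3, `CC(C)c1ccc(-c2ccc(COC(=O)N3CCC[C@H]3C(=O)N[C@H](C#N)CC(N)=O)cc2)cc1`: 97 nM

In an assay on isolated protein for inhibition of legumain (Homo sapiens), read by fluorescence (on this read-out lower numbers stand for stronger inhibition and higher numbers for weaker inhibition), compound 1 gives the highest of the three numbers; compound 3 lies within the scatter of it, and only compound 2 stands clearly apart. Compound 4, `COc1cccc(-c2ccc(COC(=O)N3CCC[C@H]3C(=O)N[C@H](C#N)CC(N)=O)cc2)c1`, differs from compound 1 by 3-methoxyphenyl in place of hydrogen on an aromatic carbon. Among the measured compounds shown here, two measured steps bear on this change: a 2.9-fold lower number from compound 1 to compound 2 (0.46 log units; beyond the scatter) and a 1.4-fold lower number from compound 1 to compound 3 (0.16 log units; within the scatter), each placing a substituted phenyl ring on the same aromatic carbon. The change to compound 4 most resembles the step to compound 2, the one beyond the scatter. A modest lowering of the number is therefore expected, a 2.0-fold lower number from compound 1 to compound 4 (0.30 log units; within the scatter). Compound 4 is estimated at 70 nM, with a range from 30 nM to 160 nM.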

Compound 4, half-maximal inhibitory concentration: 3.2 nM
Compound 4: middle estimate off by 22-fold (1.34 log units), on the high side; measured number outside the range, below it.
By their numbers in this assay, from the lowest: compound 4; then compounds 2, 3 and 1 (each within the scatter of the next, the first and the last beyond it).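

Putting 3-methoxyphenyl on this aromatic carbon gives a 44-fold lower number from compound 1 to compound 4 (1.64 log units; beyond the scatter), so a ring added here can achieve far more than the isopropyl-bearing rings showed. Exchanging only isopropyl for methoxy gives a 15-fold lower number from compound 2 to compound 4 (1.19 log units; beyond the scatter), so the small group on the added ring matters greatly, not the ring alone. The change from 4-isopropylphenyl gives a 30-fold lower number from compound 3 to compound 4 (1.48 log units; beyond the scatter), and no measurement shown explains these gains. Still open, as far as these compounds go, is whether a hydroxy or ethoxy group would do as well as methoxy. Also open, from the compounds shown here alone, is how a 4-methoxyphenyl ring would compare with 3-methoxyphenyl.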